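Swapping Methyl for Fluoro at the Far End

The source may report more compounds than this note shows. Statements on the series, on what has been measured and on what is new or still open speak of the compounds shown alone.

Of the compounds shown here, two have so far been measured in a functional assay on A-375 cells (Homo sapiens) for inhibition, read by CCK-8 assay, with a stated time of 72 h, tested at 2 uM; a lower number here means less inhibition of growth, a higher number more inhibition of growth at the concentration tested. Compound 1 `Cc1ccc(SCc2ccc(/C=C/C(=O)Nc3ccccc3N)cc2)cc1` gives 22.9% in this assay. Compound 2 `Nc1ccccc1NC(=O)c1ccc(CSc2nccc(C(F)(F)F)n2)cc1` gives 54.4% in this assay. Within the data shown here, compound 1 therefore stands lowest of the two numbers, and compound 2 lies higher by an amount beyond the usual scatter; since compound 2 differs from compound 1 in more than one place, these two values show only that the less similar compound inhibits growth more strongly at the tested concentration.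

Compound 3 `Nc1ccccc1NC(=O)/C=C/c1ccc(CSc2ccc(F)cc2)cc1` has not yet been measured. It differs from compound 1 in a single place: fluoro in place of methyl on an aromatic carbon. Everything else in the molecule is kept.

Among the measured compounds shown here, no step between measured compounds that differ in one place is available, so there is no direct precedent for this exchange. Replacing one heavy atom with one heavy atom at a single aromatic carbon is generally a modest step in a read-out of this kind. The step from compound 1 to compound 3 is expected to be small, a number 2.1 percentage points higher from compound 1 to compound 3 (within the scatter), and to fall within the scatter. Compound 3 is thus estimated to give 25% in this assay, with a likely range from 10% to 42%.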

Compound 3, percent growth inhibition at one concentration: 28.8%
The estimate for compound 3 lay 3.8 percentage points below the measured number, and the stated range covers the measured number.
By their numbers in this assay, from the lowest: compounds 1 and 3 (each within the scatter of the next); then compound 2.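

In this assay, placing fluoro where methyl stood, on an aromatic carbon para to a large group, gives a number 5.9 percentage points higher from compound 1 to compound 3 (within the scatter). Among these compounds, this is the first exchange here that can be read at a single place, and it shows that 4-methylphenyl and 4-fluorophenyl cannot be told apart in this growth read-out at the tested concentration, so this pair of small groups gives no sign that the position responds to such a swap. Nothing available here offers an explanation for this result.

As far as these compounds go, the two groups tried at this position each add only one heavy atom and carry no charge, so it stays open whether a larger or charged group, such as a methoxy group, an amine or a carboxylic acid, would shift growth inhibition beyond the scatter. Compound 2 differs from compound 1 and compound 3 in more than one place, so these compounds do not show which of its features goes with its separate number.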